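The source may hold more compounds than are shown below. What is called first, only, known or untested is meant among the compounds shown, and "the series" means these compounds.

In a functional assay on SK-BR-3 cells (Homo sapiens) for antiproliferative activity (on this read-out lower numbers stand for stronger inhibition and higher numbers for weaker inhibition), three compounds sharing one core have been measured: compound 1 (`CC(=O)Oc1ccc(C(=O)Nc2cc3ccc(OCC4CCCN(C)C4)c(C)c3oc2=O)cc1CC=C(C)C`) gives 740 nM, compound 2 (`CC(=O)Oc1ccc(C(=O)Nc2cc3ccc(OCC4CCN(C)C4)c(C)c3oc2=O)cc1CC=C(C)C`) gives 880 nM, and compound 3 (`CC(=O)Oc1ccc(C(=O)Nc2cc3ccc(OCCC4CCCCN4)c(C)c3oc2=O)cc1CC=C(C)C`) gives 640 nM. All three values lie within the usual scatter of one another, so compound 3 cannot be told apart from the other two. Compound 4 (`CC(C)=CCc1cc(C(=O)Nc2cc3ccc(OCCC4CCCCN4)c(C)c3oc2=O)ccc1O`) differs from compound 3 by a single change, hydrogen in place of acetyl on an oxygen on an aromatic ring, or acetoxy to hydroxy: hydrogen in place of acetyl on an oxygen on an aromatic ring. For the measured compounds named here, none of the measured steps touches that place. Each instead exchanges the group on a saturated chain carbon bound to an oxygen on an aromatic ring: a 1.2-fold higher number from compound 1 to compound 2 (0.08 log units; within the scatter), a 1.2-fold lower number from compound 1 to compound 3 (0.06 log units; within the scatter) and a 1.4-fold lower number from compound 2 to compound 3 (0.14 log units; within the scatter). Going by the values given here, they bear on the new change only indirectly, and the data contain no other pair with acetoxy to hydroxy. No shift beyond the scatter is therefore expected in this assay, although this expectation is loosely founded. The expected step is a 1.1-fold lower number from compound 3 to compound 4 (0.03 log units; within the scatter). The estimated value for compound 4 is 600 nM, with an expected range of 200 nM to 1800 nM.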

Compound 4, half-maximal inhibitory concentration: 640 nM
Beside the measured number, compound 4's estimate is 1.1-fold (0.03 log units) below it, within the range that was stated.
By their numbers in this assay, from the lowest: compounds 3, 4, 1 and 2 (each within the scatter of the next).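

The earlier compounds shown here differed only in the group on the saturated chain carbon, so they showed nothing about the acetoxy group. In this assay, hydrogen in place of acetyl on an oxygen on an aromatic ring gives no change at the digits printed from compound 3 to compound 4 (within the scatter), so the acetoxy and hydroxy forms cannot be told apart in this pair, and losing the acetyl with its 3 heavy atoms leaves the read-out where it was. Nothing available explains this outcome.

From the compounds shown here alone, this is a single pair with the (piperidin-2-yl)methyl group, so whether the same holds with the 1-methylpiperidin-3-yl group of compound 1 or the 1-methylpyrrolidin-3-yl group of compound 2 remains open. Going by these compounds, how a methyl ether or a longer acyl chain such as butanoyl on that oxygen would read in this assay also remains open.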